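Hydroxy for carboxy on the aromatic ring: expected gain

The source may hold more compounds than are shown below. What is called first, only, known or untested is meant among the compounds shown, and "the series" means these compounds.

Compound 1 `CC1(C)CCC[C@]2(C)[C@@H](Cc3cc(C(=O)O)ccc3O)[C@](C)(O)CC[C@@H]12`: > 50000 nM
Compound 2 `Cc1cc(O)cc(O)c1C[C@@H]1[C@@]2(C)CCCC(C)(C)[C@@H]2CC[C@@]1(C)O`: 11100 nM
Compound 3 `Cc1cc(O)c(C[C@@H]2[C@@]3(C)CCCC(C)(C)[C@@H]3CC[C@@]2(C)O)c(O)c1`: 10400 nM

All three were tested in a functional assay on HepG2 cells (Homo sapiens) for inhibition, read by MTT assay, with a stated time of 72 h; on this read-out lower numbers stand for an effect already at smaller amounts and higher numbers for an effect only at larger amounts of compound. Compound 1 gives only a limit, > 50000 nM, not a number (the limit of > 50000 nM in this assay, at which 1 of the 3 values shown sits). Compound 2 gives 11100 nM and compound 3 gives 10400 nM; these two values lie within the usual scatter of each other.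

Compound 4 `CC1(C)CCC[C@]2(C)[C@@H](Cc3cc(O)ccc3O)[C@](C)(O)CC[C@@H]12` has not been measured. It differs from compound 1 by hydroxy in place of carboxy on an aromatic carbon and so, like compound 2 and compound 3, carries hydroxy rather than carboxy on the aromatic ring. Compound 4 is therefore expected to land near those two, at about 15000 nM (range 5000 nM to 50000 nM). The expected step of an at least 3.3-fold lower number from compound 1 to compound 4 (0.52 log units; beyond the scatter) is a gain beyond the scatter, its exact size uncertain because compound 1 sits at the limit (the limit of > 50000 nM in this assay, at which 1 of the 3 values shown sits).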

Compound 4, half-maximal effective concentration: > 50000 nM
Compound 4: a limit, no number; the forecaster's own chance of this, stated with the estimate: 20%; at least 3.3-fold (0.52 log units) between middle value and limit.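

Among these compounds, compound 1 and compound 4 both sit at a limit rather than a number, so no step between them can be read: the limit of > 50000 nM in this assay, at which 2 of the 4 values shown sit. The compounds shown leave open whether hydroxy in place of carboxy on this aromatic carbon changes the effect at all.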